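This account rests on a few compounds, and the source may have more. Where it says the series, first, only, none or still open, it means among the compounds named here.

Working notes on the series. Compound 1 `CC(C)C[C@H](N)c1cc(C(F)(F)F)ccc1N1CCN(C(=O)CCC(N)=O)CC1`, compound 2 `COc1ccc(CC(C)C(=O)N2CCN(c3ccc(C(F)(F)F)cc3[C@@H](N)CC(C)C)CC2)cc1`, compound 3 `Cc1cc(CC(C)C(=O)N2CCN(c3ccc(C(F)(F)F)cc3[C@@H](N)CC(C)C)CC2)ccc1Cl` and compound 4 `CCOc1cccc(CC(C)C(=O)N2CCN(c3ccc(C(F)(F)F)cc3[C@@H](N)CC(C)C)CC2)c1` share one core and differ only in the group on the carbonyl carbon. Among the measured compounds shown here, in an assay on HEK293 cells for displacement of a labelled ligand from Melanocortin receptor 4 (Homo sapiens) (a lower number here means a stronger inhibitor, a higher number a weaker inhibitor), compound 1 gives only a limit, > 10000 nM, and is the one member here that stands at that limit (the limit of > 10000 nM in this assay, at which 1 of the 3 values shown sits). In this assay compound 2 gives 120 nM and compound 3 gives 71 nM; the step of a 1.7-fold lower number from compound 2 to compound 3 (0.23 log units; within the scatter) lies within the scatter. The change to compound 4 is 1-(3-ethoxybenzyl)ethyl in place of 2-carbamoylethyl on a carbonyl carbon. The two measured steps of the same kind, an at least 83-fold lower number from compound 1 to compound 2 (1.92 log units; beyond the scatter) and an at least 140-fold lower number from compound 1 to compound 3 (2.14 log units; beyond the scatter), were both large, so the step expected for compound 4 is an at least 100-fold lower number from compound 1 to compound 4 (2.00 log units; beyond the scatter). Compound 4 is expected at 100 nM, within 30 nM to 400 nM.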

Compound 4, inhibition constant: 2200 nM
Beside the measured number, compound 4's estimate is 22-fold (1.34 log units) below it; the whole stated range lies below it.
By their numbers in this assay, from the lowest: compounds 3 and 2 (each within the scatter of the next); then compound 4. At a limit, above all of these: compound 1.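

The aryl group on this saturated chain carbon is not interchangeable in this assay: a 31-fold higher number from compound 3 to compound 4 (1.49 log units; beyond the scatter) and an 18-fold higher number from compound 2 to compound 4 (1.26 log units; beyond the scatter), so 3-ethoxyphenyl separates from the two earlier aryl groups, which lie within the scatter of each other. Replacing 2-carbamoylethyl with 1-(3-ethoxybenzyl)ethyl still gives an at least 4.5-fold lower number from compound 1 to compound 4 (0.65 log units; beyond the scatter), but that step is measured against a limit rather than a number: the limit of > 10000 nM in this assay, at which 1 of the 4 values shown sits.

Whether the ethoxy group itself or its place on the ring accounts for the weaker binding remains open. Also open, from the compounds shown here alone, is how an unsubstituted phenyl ring or a carboxylic acid on that ring would read.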